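Benzyloxy anilines on a shared core: nitro for trifluoromethyl

The compounds below may be only part of what the source reports. "The series", "measured", "known", "first", "only" and "open" are said of these compounds alone.

Compound 1 `c1ccc(COc2ccccc2Nc2ncnc3cc4c(cc23)OCCOCCO4)cc1` carries a benzyloxy-substituted aniline on the shared core. In a functional assay on HepG2 cells (Homo sapiens) for antiproliferative activity, read by MTT assay, with a stated time of 72 h (on this read-out lower numbers stand for stronger inhibition and higher numbers for weaker inhibition), compound 1 reaches only the limit of the assay, > 100000 nM. Compound 2 `FC(F)(F)c1ccc(COc2ccccc2Nc2ncnc3cc4c(cc23)OCCOCCO4)cc1` adds trifluoromethyl in place of hydrogen on an aromatic carbon. In this assay compound 2 likewise stops at the limit, > 100000 nM. The step that the two limits leave unreadable from compound 1 to compound 2 is therefore unreadable, its size hidden by the two limits. Compound 3 `c1ccc(COc2ccc(Nc3ncnc4cc5c(cc34)OCCOCCO5)cc2)cc1` is an isomer of compound 1. In this assay compound 3 gives 55500 nM.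

Compound 4 `O=[N+]([O-])c1ccc(COc2ccccc2Nc2ncnc3cc4c(cc23)OCCOCCO4)cc1` differs from compound 2 by nitro in place of trifluoromethyl on an aromatic carbon. Among the measured compounds shown here, no measured step bears directly on this change: the only step available, a step that the two limits leave unreadable from compound 1 to compound 2, cannot be sized. Compound 2 stands at the limit in this assay, and because of the limit of > 100000 nM in this assay, at which 2 of the 3 values shown sit, a further limit rather than a number is the more probable outcome for compound 4. The expected step of a number no higher from compound 2 to compound 4 (the limit leaves the size open) is accordingly none beyond the scatter. Compound 4 is therefore estimated at 100000 nM in this assay, within a range from 30000 nM to 300000 nM.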

Compound 4, half-maximal inhibitory concentration: 50200 nM
The estimate for compound 4 lay 2.0-fold (0.30 log units) above the measured number, within the range that was stated.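

In this assay, the position para to a large group gives a readable number with nitro, whereas hydrogen and trifluoromethyl there stop at a limit: the limit of > 100000 nM in this assay, at which 2 of the 4 values shown sit.

Nitro in place of trifluoromethyl gives an at least 1.9-fold lower number from compound 2 to compound 4 (0.29 log units; that floor lies within the scatter), and nitro in place of hydrogen gives an at least 1.9-fold lower number from compound 1 to compound 4 (0.29 log units; that floor lies within the scatter). Both floors lie within the scatter, so the series shows that this position can carry a group with a measurable value but does not show a gain beyond the scatter, and the step from hydrogen to trifluoromethyl cannot be read.

From the compounds shown here alone, how far the true values of compound 1 and compound 2 lie from that of compound 4 stays open. Also open, going by these compounds, is what an amine or a carboxylic acid would give at this position, and whether nitro would act in the same way on compound 3, the isomer of compound 1.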